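Cytotoxicity notes on a cyclic sulfonate nucleoside series

The source may report more compounds than this note shows. Statements on the series, on what has been measured and on what is new or still open speak of the compounds shown alone.

Measured so far:
compound 1 `Cc1cn([C@@H]2O[C@H](CO[Si](C)(C)C(C)(C)C)[C@@]3(OS(=O)(=O)C=C3NCC(N)=O)[C@H]2O[Si](C)(C)C(C)(C)C)c(=O)n(C)c1=O` gives 13500 nM in a functional assay on HEL cells (Homo sapiens); a higher number here means that more compound is tolerated, a lower number that less compound is tolerated;
compound 2 `COC(=O)CNC1=CS(=O)(=O)O[C@@]12[C@@H](CO[Si](C)(C)C(C)(C)C)O[C@@H](n1cc(C)c(=O)n(C)c1=O)[C@@H]2O[Si](C)(C)C(C)(C)C` gives 160000 nM in this assay.

Among the compounds with values here, compound 1 stands lowest of the two numbers; the only measured step, a 12-fold higher number from compound 1 to compound 2 (1.07 log units; beyond the scatter), is large. Compound 3 `Cc1cn([C@@H]2O[C@H](CO[Si](C)(C)C(C)(C)C)[C@@]3(OS(=O)(=O)C=C3NC(N)=O)[C@H]2O[Si](C)(C)C(C)(C)C)c(=O)n(C)c1=O` differs from compound 1 as follows: carbamoyl in place of carbamoylmethyl on an amine nitrogen. Within the data shown here, no measured step bears directly on this change; the step from compound 1 to compound 2 alters the carbonyl substituent, not the chain on the amine nitrogen. A step within the scatter is therefore expected, a 1.1-fold higher number from compound 1 to compound 3 (0.05 log units; within the scatter), with compound 3 estimated at 15000 nM (range 5000 nM to 45000 nM).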

Compound 3, half-maximal cytotoxic concentration: 11000 nM
Estimate against measurement, compound 3: 1.4-fold (0.13 log units) above; the range from low to high includes it.
By their numbers in this assay, from the lowest: compounds 3 and 1 (each within the scatter of the next); then compound 2.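

In this assay, replacing carbamoylmethyl with carbamoyl on the amine nitrogen leaves the number within the scatter (a 1.2-fold lower number from compound 1 to compound 3 (0.09 log units; within the scatter)), so the ureido and (carbamoylmethyl)amino forms cannot be told apart here. The large gap to the methyl ester persists with the shorter group (a 15-fold lower number from compound 2 to compound 3 (1.16 log units; beyond the scatter)), and compound 3 sits with compound 1 rather than with compound 2. Nothing available explains either step.

Open, as far as these compounds go, is whether a carboxylic acid on the same chain, or a longer chain ending in the primary amide, would stay with compound 1 and compound 3 or move toward compound 2.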